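A Chlorine Moved Around the Benzoyl Ring

The source may hold more compounds than are shown below. What is called first, only, known or untested is meant among the compounds shown, and "the series" means these compounds.

For the measured compounds named here, compound 3 `O=C(Nc1ccccc1C(F)(F)F)C1CCc2ccccc2N1C(=O)c1ccc(Cl)cc1` gives 786 nM in a functional assay on PC-3 cells (Homo sapiens) for cytotoxicity, read by sulforhodamine B assay, with a stated time of 72 h (on this read-out higher numbers stand for weaker inhibition of growth and lower numbers for stronger inhibition of growth), the second highest of the three numbers known. Compound 1 `O=C(Nc1ccccc1C(F)(F)F)C1CCc2ccccc2N1C(=O)c1cccc(Cl)c1` gives 729 nM, and compound 2 `O=C(Nc1ccccc1C(F)(F)F)C1CCc2ccccc2N1C(=O)c1ccccc1` gives 5560 nM. Compound 4 `O=C(Nc1ccccc1C(F)(F)F)C1CCc2ccccc2N1C(=O)c1ccccc1Cl` differs from compound 3 by 2-chlorophenyl in place of 4-chlorophenyl on a carbonyl carbon. Two kinds of step are known: a change of the chlorine's place, a 1.1-fold higher number from compound 1 to compound 3 (0.03 log units; within the scatter), and the arrival of chlorine on a ring that had none, a 7.1-fold lower number from compound 2 to compound 3 (0.85 log units; beyond the scatter). Going by the values given here, only the chlorine's place changes here, and the one known change of place stayed within the scatter, so a small step is expected, a 1.8-fold higher number from compound 3 to compound 4 (0.25 log units; within the scatter), with some room toward higher numbers. Compound 4 is therefore expected to give 1400 nM, most likely between 400 nM and 5500 nM.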

Compound 4, concentration for 50% growth inhibition: 5140 nM
Compound 4: middle estimate off by 3.7-fold (0.56 log units), on the low side; the range from low to high includes it.
By their numbers in this assay, from the lowest: compounds 1 and 3 (each within the scatter of the next); then compounds 4 and 2 (each within the scatter of the next).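

The chlorine's place on this ring does matter: 2-chlorophenyl in place of 4-chlorophenyl on the carbonyl carbon gives a 6.5-fold higher number from compound 3 to compound 4 (0.82 log units; beyond the scatter), and 2-chlorophenyl in place of 3-chlorophenyl gives a 7.1-fold higher number from compound 1 to compound 4 (0.85 log units; beyond the scatter). Chloro at this new place brings no gain over the bare ring, with a 1.1-fold lower number from compound 2 to compound 4 (0.03 log units; within the scatter), so the earlier gain from chlorine holds for the 3-chlorophenyl and 4-chlorophenyl groups but not for 2-chlorophenyl. Nothing shown here explains this difference between the three chlorine places. From the compounds shown here alone, whether a fluoro or a methoxy group at that same place would give numbers like those of compound 2 or those of compound 3 remains open.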